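Trimming the Methyl From the Ring of Compound 3

A few compounds are considered here, and "the series" means these few. Any claim that something is new, unique, unknown or untested is made for them only; others in the source may bear on it.

Compound 1 `CN(Cc1ccccc1F)C(=O)CNC(=O)c1ccc(S(C)(=O)=O)c([N+](=O)[O-])c1`, compound 2 `CC(C)N(C(=O)CNC(=O)c1ccc(S(C)(=O)=O)c([N+](=O)[O-])c1)C(C)C` and compound 3 `CC1CCN(C(=O)CCCNC(=O)c2ccc(S(C)(=O)=O)c([N+](=O)[O-])c2)CC1` share a common core and differ only in the amide-bound end. Each was tested in an assay on isolated protein for inhibition of vitamin D3 receptor (Homo sapiens), read by fluorescence polarization; a lower number here means a stronger inhibitor, a higher number a weaker inhibitor. Compound 1 reaches only the limit of the assay, > 60000 nM. Compound 2 likewise stops at the limit, > 60000 nM. Compound 3 also gives a limit rather than a number, > 60000 nM. So compound 3 stands nowhere in particular among the three: every value shown sits at the limit of > 60000 nM in this assay, at which 3 of the 3 values shown sit, and no step between measured compounds can be sized.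

Compound 4 `CS(=O)(=O)c1ccc(C(=O)NCCCC(=O)N2CCCCC2)cc1[N+](=O)[O-]` is compound 3 with a single change: hydrogen in place of methyl on a saturated ring carbon. No measured step offers a guide, and a change this small gives no reason to expect a move beyond the scatter. Compound 4 is therefore expected to remain at the limit, with an estimated 100000 nM and a range from 30000 nM to 300000 nM. The expected step is a step that the limit leaves unreadable from compound 3 to compound 4, nothing beyond the scatter.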

Compound 4, half-maximal inhibitory concentration: > 60000 nM
Compound 4 was reported as a limit (the forecaster's own chance of this, stated with the estimate: 85%); the middle value does not contradict the limit.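

Compound 3 and compound 4 each give a limit rather than a number, so no step can be read between them: the limit of > 60000 nM in this assay, at which 4 of the 4 values shown sit. The compounds shown leave open whether any amide-bound end gives a readable value in this assay, and whether trading the methyl for hydrogen matters at all.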